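The source may hold more compounds than are shown below. What is called first, only, known or untested is meant among the compounds shown, and "the series" means these compounds.

Measured in a functional assay on LoVo cells (Homo sapiens) for cytotoxicity, read by colorimetric assay and MTT assay; on this read-out lower numbers stand for stronger inhibition and higher numbers for weaker inhibition:
- compound 1 `COc1cccc2cc(-c3ccccc3)c(O)nc12`: 10000 nM
- compound 2 `COc1ccc(-c2cc3c(OC)cc(OC)cc3n(CCCC#N)c2=O)cc1`: 10000 nM

Compound 2, at 10000 nM, stands level with compound 1, and the two values lie within the scatter of each other. Going by the values given here, no pair of measured compounds differs in one place, so the data hold no measured step to guide a forecast. Compound 3 `CCN(CC)C(=O)CCn1c(=O)c(-c2ccc(OC)cc2)cc2c(OC)cc(OC)cc21`, still unmeasured, has diethylcarbamoyl in place of cyanomethyl on a saturated chain carbon, two bonds along the chain from an aromatic nitrogen. With only compound 2 at 10000 nM as its reference, no shift beyond the scatter is expected in this assay, in either direction. The estimated change is no change at the digits printed from compound 2 to compound 3 (within the scatter). For compound 3 the expected value is 10000 nM, within an estimated range from 3000 nM to 30000 nM.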

Compound 3, half-maximal inhibitory concentration: 10000 nM
Beside the measured number, compound 3's estimate shows no gap at the digits printed; the measured number falls inside the stated range.
By their numbers in this assay, from the lowest: compounds 1, 2 and 3 (each within the scatter of the next).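

In this assay, going by these compounds alone, putting diethylcarbamoyl in place of cyanomethyl on a saturated chain carbon, two bonds along the chain from an aromatic nitrogen, gives no change at the digits printed from compound 2 to compound 3 (within the scatter), the only measured step in this set. At this position, then, the nitrile end of the chain can give way to a diethylcarbamoyl group of 7 heavy atoms, against 3 for cyanomethyl, without the read-out leaving the scatter in either direction. No measurement on hand bears on what lies behind this result.

From the compounds shown here alone, what an amine or a carboxylic acid at the end of this chain, or a longer chain, would give remains open. All three compounds stand level, so the set does not yet show which change, on the chain or on the shared core, would move the number at all.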